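This account rests on a few compounds, and the source may have more. Where it says the series, first, only, none or still open, it means among the compounds named here.

Measured in a functional assay on K562 cells (Homo sapiens), read by MTT assay, with a stated time of 72 h; on this read-out higher numbers stand for weaker inhibition and lower numbers for stronger inhibition:
- Compound 1 `Cc1ncnc2c1c(-c1ccoc1)cn2[C@@H]1O[C@H](CO)[C@@H](O)[C@H]1O`: > 20000 nM
- Compound 2 `Nc1nc(N)c2c(-c3cccs3)cn([C@@H]3O[C@H](CO)[C@@H](O)[C@H]3O)c2n1`: > 20000 nM
- Compound 3 `Cc1nc(N)c2c(-c3cccs3)cn([C@@H]3O[C@H](CO)[C@@H](O)[C@H]3O)c2n1`: > 20000 nM

Each of these entries is a limit of the assay and not a number. Compound 3 therefore has no exact position, and it shares its place with the other two: the limit of > 20000 nM in this assay, at which 3 of the 3 values shown sit.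

Compound 4 `C#Cc1cn([C@@H]2O[C@H](CO)[C@@H](O)[C@H]2O)c2nc(C)nc(N)c12` differs from compound 3 by one change, ethynyl in place of thiophen-2-yl on an aromatic carbon. The only measured step among these compounds is a step that the two limits leave unreadable from compound 2 to compound 3. It involves a different change, methyl in place of amino on an aromatic carbon, and it gives no size that could be carried over. For the measured compounds named here, no measured step tests a replacement of thiophen-2-yl, so any forecast is loose.

Compound 4 has no ring at this place, whereas compound 3 carries one there. That difference leaves room for some activity to appear in this assay, although staying at the limit is just as plausible.

The expected move is toward stronger inhibition, with an estimated step of an at least 2.5-fold lower number from compound 3 to compound 4 (0.39 log units; beyond the scatter). For compound 4 the estimated value is 8000 nM. The estimated range for compound 4 runs from 500 nM to 20000 nM.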

Compound 4, half-maximal inhibitory concentration: 3290 nM
The estimate for compound 4 lay 2.4-fold (0.39 log units) above the measured number; measured number inside the range.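

In this assay, replacing thiophen-2-yl with ethynyl on this aromatic carbon gives an at least 6.0-fold lower number from compound 3 to compound 4 (0.78 log units; beyond the scatter). For the compounds shown here, this shows that the group at this place can decide whether the compound gives a readable value at all, something the earlier compounds could not show. Compound 4 is the only one of these compounds to come off the limit that holds all the others: the limit of > 20000 nM in this assay, at which 3 of the 4 values shown sit.

This single pair swaps a ring for a group with no ring and a triple bond, so it cannot say whether losing the ring or gaining the triple bond matters; a ringless group without a triple bond, such as ethyl, or a longer chain ending in a triple bond, such as propargyl, would begin to separate the two. As far as these compounds go, the step between the amino and methyl compounds cannot be read, since both of its ends are limits, so the effect of that exchange also stays open, and an amino group in place of the methyl of compound 4 would test it on a compound with a measurable value.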